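A few compounds are considered here, and "the series" means these few. Any claim that something is new, unique, unknown or untested is made for them only; others in the source may bear on it.

Compound 1 `COc1cc(F)ccc1-c1ccnc2[nH]c(C3CCN(CC(=O)N(C)C)CC3)cc12`: 2.9
Compound 2 `COc1cc(C(=O)N2CCCC2)ccc1-c1ccnc2[nH]c(C3CCOCC3)cc12`: 3

These two numbers come from a physicochemical assay for lipophilicity, using the shake flask method, measured as octanol-water partition, at pH 7.4; on this read-out higher numbers stand for higher lipophilicity and lower numbers for lower lipophilicity. Going by the values given here, compound 1 and compound 2 lie within the usual scatter of each other, so compound 1 stands level with the only other measured compound. Compound 3 `CCn1cc(-c2ccnc3[nH]c(C4CCN(CC(=O)N(C)C)CC4)cc23)ccc1=O` differs from compound 1 in one place: a group of 9 heavy atoms (7 carbon, 1 nitrogen, 1 oxygen; one six-membered aromatic ring with 1 hetero atom) in place of a group of 9 heavy atoms (7 carbon, 1 oxygen, 1 fluorine; one six-membered aromatic ring of carbon only), on an aromatic carbon. Among the compounds with values here, no measured pair shows a swap of this kind, so the expectation rests on the structural change alone. A drop beyond the scatter is expected, an estimated a number 1.00 log units lower from compound 1 to compound 3 (beyond the scatter). The estimated value for compound 3 is 1.9, with an expected range from 1.4 to 2.4.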

Compound 3, distribution coefficient: 1.2
Beside the measured number, compound 3's estimate is 0.70 log units above it, outside the stated range (below it).
By their numbers in this assay, from the lowest: compound 3; then compounds 1 and 2 (each within the scatter of the next).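

In this assay, the place opposite the ring nitrogen of the shared core proves far from neutral: exchanging 4-fluoro-2-methoxyphenyl for a six-membered aromatic ring with a hetero atom gives a number 1.70 log units lower from compound 1 to compound 3 (beyond the scatter) and is a large step. The two groups hold the same count of heavy atoms, so size by that count stays level. No measurement shown here explains the step. Going by these compounds, the ring nitrogen, the carbonyl and the loss of fluorine and methoxy change together, so which of them carries the step stays open. On these data alone, how an amine or a carboxylic acid at this place would read also stays open.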